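Amide side-chain swap in a pyrrole-carboxamide series

The compounds below may be only part of what the source reports. "The series", "measured", "known", "first", "only" and "open" are said of these compounds alone.

Of the compounds shown here, two have been measured in a functional assay on PC-3 cells (Homo sapiens) for antiproliferative activity, read by MTT assay, with a stated time of 72 h; on this read-out lower numbers stand for stronger inhibition and higher numbers for weaker inhibition. Compound 1 `CCn1c(C(=O)NCCC(=O)O)ccc1C(CC)(CC)c1ccc(C#CC(O)(CC)CC)c(C)c1` gives 5130 nM. Within the data shown here, compound 2 `CCn1cc(C(CC)(CC)c2ccc(C#CC(O)(CC)CC)c(C)c2)cc1C(=O)NCCN(C)C` gives 10100 nM, the only other number available; the gap between compound 2 and compound 1 lies within the scatter of repeated measurements, so compound 2 stands alongside compound 1 rather than apart from it. Compound 3 `CCn1cc(C(CC)(CC)c2ccc(C#CC(O)(CC)CC)c(C)c2)cc1C(=O)NCCC(=O)O` remains to be measured in this assay. It differs from compound 2 in one place: carboxy in place of dimethylamino on a saturated chain carbon, two bonds along the chain from an amide-type nitrogen. Among the measured compounds shown here, no step between measured compounds isolates this change; compound 1 and compound 2 differ in more places than this one, so only their two values, which overlap, can be read. From that overlap no shift beyond the scatter is expected, and the step of a 1.6-fold lower number from compound 2 to compound 3 (0.19 log units; within the scatter) is an estimate of little change. Compound 3 is estimated at 6500 nM, within 2500 nM to 17000 nM.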

Compound 3, half-maximal inhibitory concentration: > 50000 nM
Compound 3 was reported as a limit; the forecaster's own chance of this, stated with the estimate: 2%; middle value at least 7.6-fold (0.88 log units) away from the limit.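

In this assay, the amide side chain of the core shared by compound 2 and compound 3 proves sensitive: carboxy in place of dimethylamino, on a saturated chain carbon two bonds along the chain from an amide-type nitrogen, gives an at least 4.9-fold higher number from compound 2 to compound 3 (0.69 log units; beyond the scatter). Compound 1 also carries the 2-carboxyethyl group and gives 5130 nM. Compound 3 is reported only as a limit, so the full size of this step stays unfixed: the limit of > 50000 nM in this assay, at which 1 of the 3 values shown sits.

What the compounds shown leave open is whether the loss belongs to the carboxylic acid itself or to the removal of the dimethylamino group. A methyl ester, a primary amine or a longer chain ending in a carboxylic acid at this place would bear on that question.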